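The source may hold more compounds than are shown below. What is called first, only, known or untested is meant among the compounds shown, and "the series" means these compounds.

Compound 3 `CC(C)(C)c1ccc(C(=O)N2CCC3(CC2)C(=O)N(CC(=O)NCN)CN3c2ccccc2)cc1` is assessed in an assay on HEK293 cells for displacement of a labelled ligand from NPC1-like intracellular cholesterol transporter 1 (Homo sapiens) (a higher number here means a weaker inhibitor, a lower number a stronger inhibitor), where compound 3 gives 26500 nM, the highest of the three numbers recorded. Its nearest neighbour is compound 1 `CC(C)(C)OC(=O)NCCNC(=O)CN1CN(c2ccccc2)C2(CCN(C(=O)c3ccc(C(C)(C)C)cc3)CC2)C1=O`, for which compound 1 gives 10900 nM; the furthest is compound 2 `CC(C)(C)c1ccc(C(=O)N2CCC3(CC2)C(=O)N(CC(=O)NCCO)CN3c2ccccc2)cc1`, where compound 2 gives 1000 nM. The step of a 2.4-fold higher number from compound 1 to compound 3 (0.39 log units; beyond the scatter) is modest, whereas a 27-fold higher number from compound 2 to compound 3 (1.42 log units; beyond the scatter) is large, and an 11-fold lower number from compound 1 to compound 2 (1.04 log units; beyond the scatter) is large in the opposite sense.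

Compound 4 `CC(C)(C)c1ccc(C(=O)N2CCC3(CC2)C(=O)N(CC(=O)NCCCN)CN3c2ccccc2)cc1` differs from compound 3 by 2-aminoethyl in place of amino on a saturated chain carbon bound to an amide-type nitrogen. Among the compounds with values here, two measured steps bear on it: a 27-fold higher number from compound 2 to compound 3 (1.42 log units; beyond the scatter) and a 2.4-fold higher number from compound 1 to compound 3 (0.39 log units; beyond the scatter), both of which saw the number rise when a longer terminal carbon chain in this position was cut back to a bare amino group. From the compounds shown here alone, compound 4 restores a chain of comparable length, ending in an amino group rather than a hydroxy or a (tert-butoxycarbonyl)amino group, so a lower number is expected in this assay, though it is unknown whether it will match compound 2 or fall nearer compound 1. The step from compound 3 to compound 4 is expected to be a 7.6-fold lower number from compound 3 to compound 4 (0.88 log units; beyond the scatter). Compound 4 is therefore estimated at 3500 nM, with a range from 900 nM to 13000 nM.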

Compound 4, half-maximal inhibitory concentration: 4200 nM
Estimate against measurement, compound 4: 1.2-fold (0.08 log units) below; the range from low to high includes it.
By their numbers in this assay, from the lowest: compound 2; then compound 4; then compound 1; then compound 3.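

In this assay, 2-aminoethyl in place of amino on a saturated chain carbon bound to an amide-type nitrogen gives a 6.3-fold lower number from compound 3 to compound 4 (0.80 log units; beyond the scatter) and so shows that this position responds to chain length even when the chain still ends in an amino group. The end of the chain also counts: aminomethyl in place of hydroxy gives a 4.2-fold higher number from compound 2 to compound 4 (0.62 log units; beyond the scatter) while aminomethyl in place of (tert-butoxycarbonyl)amino gives a 2.6-fold lower number from compound 1 to compound 4 (0.41 log units; beyond the scatter) and so the amine-ended chain falls between the hydroxy-ended and the carbamate-ended ones. Nothing in the data at hand accounts for either the chain-length effect or the effect of the chain end.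

The compounds shown leave open whether a still longer aminoalkyl chain would continue this trend or reverse it, and whether a dimethylamine at the chain end would behave like the primary amine. They also leave open how a carboxylic acid or a methyl ether at the same chain end would compare with the hydroxy group of compound 2, which remains the lowest number in this small set.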